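Chloro to methoxy on the pendant ring: an expected step

The source may hold more compounds than are shown below. What is called first, only, known or untested is meant among the compounds shown, and "the series" means these compounds.

Measured so far:
compound 1 `Oc1cc(C(F)(F)F)ccc1-c1nc(-c2ccccc2O)n(-c2ccccc2Cl)n1` — 90.6%
compound 2 `Oc1cc(C(F)(F)F)ccc1-c1nc(-c2ccccc2O)n(-c2cccc(Cl)c2)n1` — 92.7%

In a functional assay on PC-12 cells (Rattus norvegicus) for cytotoxicity, read by MTT assay, with stated times of 2 h and 24 h, tested at 5 uM (a higher number here means a stronger effect of the compound at the concentration tested, a lower number a weaker effect), compound 1 gives 90.6% and compound 2 gives 92.7%. Compound 2 stands as the higher of the two numbers, but the step of a number 2.1 percentage points higher from compound 1 to compound 2 (within the scatter) lies within the scatter, so the two compounds cannot be told apart on these readings. Compound 3 `COc1cccc(-n2nc(-c3ccc(C(F)(F)F)cc3O)nc2-c2ccccc2O)c1` has not yet been measured. It differs from compound 2 by methoxy in place of chloro on an aromatic carbon. Within the data shown here, the single measured step, a number 2.1 percentage points higher from compound 1 to compound 2 (within the scatter), concerned only where the chloro sits and not its replacement, so no measured step bears directly on this change; it shows only that one small alteration on that ring left the read-out essentially unchanged. On that slender basis the step is expected to be a number 2.7 percentage points lower from compound 2 to compound 3 (within the scatter), with no movement beyond the scatter. Compound 3 is accordingly estimated at 90%, within a range from 76% to 99%.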

Compound 3, a percentage reported as activity, at one concentration (the size of the read-out at that concentration, not a potency): 96.8%
Estimate against measurement, compound 3: 6.8 percentage points below; measured number inside the range.
By their numbers in this assay, from the lowest: compounds 1, 2 and 3 (each within the scatter of the next).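

In this assay, among these compounds, this is the first measured exchange of the group itself rather than of its place: methoxy for chloro on the ring gives a number 4.1 percentage points higher from compound 2 to compound 3 (within the scatter), so the two groups cannot be told apart here, although methoxy brings one hydrogen-bond acceptor and chloro none. Changing the group and its place together, with 3-methoxyphenyl in place of 2-chlorophenyl on the aromatic nitrogen, gives a number 6.2 percentage points higher from compound 1 to compound 3 (within the scatter), so even this double alteration leaves the compounds indistinguishable. Nothing available explains this steady read-out.

From the compounds shown here alone, all three compounds carry small neutral groups on this ring, so it remains open whether an amine, a carboxylic acid or a longer chain such as butoxy would move the number beyond the scatter. Also open, going by these compounds, is how methoxy would behave in the place the chloro of compound 1 occupies.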